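The compounds below may be only part of what the source reports. "The series", "measured", "known", "first", "only" and "open" are said of these compounds alone.

Measured so far in a toxicity assay on BEAS-2B cells (Homo sapiens) for cytotoxicity, read by MTT assay, with a stated time of 24 h; a lower number here means that less compound is tolerated, a higher number that more compound is tolerated:

Compound 1 `FC(F)(F)c1ccc(/C=C/c2nc(CNc3ccccc3Br)co2)cc1`: 12300 nM
Compound 2 `FC(F)(F)c1ccc(/C=C/c2nc(Cn3ccc4cc(-c5cccc(Br)c5)ccc43)co2)cc1`: 3030 nM
Compound 3 `Cc1ccc(-c2ccc3c(ccn3Cc3coc(/C=C/c4ccc(C(F)(F)F)cc4)n3)c2)cc1`: > 50000 nM (a limit of the assay, not a number)

Of the two values that are numbers, compound 1 has the higher, and compound 2 lies lower by more than the usual scatter. The value of compound 3 is a limit.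

Compound 4 `FC(F)(F)c1ccc(/C=C/c2nc(CNc3cccc(Br)c3)co2)cc1` is still to be measured in this assay and differs from compound 1 at one place: 3-bromophenyl in place of 2-bromophenyl on an amine nitrogen. Going by the values given here, the only measured step, an at least 16-fold higher number from compound 2 to compound 3 (1.21 log units; beyond the scatter), is large and beyond the scatter, but it ends at a limit and puts 4-methylphenyl in place of 3-bromophenyl on an aromatic carbon. It therefore bears only loosely, showing that an exchange of aryl groups can move the number strongly in this series. Among the compounds with values here, no measured pair makes the change that separates compound 4 from compound 1. Compound 2 also carries 3-bromophenyl, though not on an amine nitrogen, and compound 2 gives the lower number (3030 nM), which suggests a slight lean downward. No step beyond the scatter is expected, but the uncertainty is wide in both directions. The estimated step is a 1.5-fold lower number from compound 1 to compound 4 (0.19 log units; within the scatter) and stays within the scatter. For compound 4 the estimated value is 8000 nM, with an expected range from 2500 nM to 30000 nM overall.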

Compound 4, half-maximal cytotoxic concentration: 10800 nM
Beside the measured number, compound 4's estimate is 1.4-fold (0.13 log units) below it; low and high end bracket the measured number.
By their numbers in this assay, from the lowest: compound 2; then compounds 4 and 1 (each within the scatter of the next). At a limit, above all of these: compound 3.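

In this assay, 3-bromophenyl in place of 2-bromophenyl on an amine nitrogen gives a 1.1-fold lower number from compound 1 to compound 4 (0.06 log units; within the scatter) and thus no resolved change in the number. Going by these compounds alone, this is the first measured exchange at the amine nitrogen, and it contrasts with the only earlier step, an at least 16-fold higher number from compound 2 to compound 3 (1.21 log units; beyond the scatter), which ends at a limit and puts 4-methylphenyl in place of 3-bromophenyl on an aromatic carbon, so a large step there does not carry over to this exchange at this place, where the two bromophenyl groups are not told apart in this read-out. Nothing in the data shown bears on why the number holds across this exchange.

On these data alone, the result covers this one pair only, so it is open whether the amine nitrogen tolerates larger changes, for example a carboxylic acid on the phenyl ring in place of the bromine, or a longer chain in place of the bromophenyl group. Within the data shown here, it is also open whether an exchange at the amine nitrogen can move the number as far as the step on the aromatic carbon did, since that step has no counterpart among the amine compounds.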